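The source may report more compounds than this note shows. Statements on the series, on what has been measured and on what is new or still open speak of the compounds shown alone.

In a functional assay on CLL cells (Homo sapiens) for cytotoxicity, read by MTT assay, with a stated time of 48 h (a higher number here means that more compound is needed for the effect, a lower number that less compound is needed), compound 1 (`C=C(CC)C(=O)c1ccc(OCC(=O)Nc2nc3ccccc3s2)c(Cl)c1Cl`) gives 1500 nM and compound 2 (`C=C(CC)C(=O)c1ccc(OCC(=O)Nc2ccc(/C=C/C(=O)O)cc2)c(Cl)c1Cl`) gives 3000 nM. These two values lie within the usual scatter of each other, so compound 2 stands level with compound 1 on the numbers available. The next compound, compound 3 (`C=C(CC)C(=O)c1ccc(OCC(=O)Nc2ccc(C(N)=O)cc2)c(Cl)c1Cl`), keeps the core of compound 2 and changes one group: carbamoyl in place of 2-carboxyethenyl on an aromatic carbon. The carbamoyl group takes the place of the 2-carboxyethenyl group on an aromatic carbon, para to a large group. Within the data shown here, no two measured compounds differ in one place only, so the effect of this change has not been observed directly. The expectation rests on compound 1 at 1500 nM and compound 2 at 3000 nM, whose structures differ by more than this single group while their values remain within the scatter. The expected change is a 1.2-fold lower number from compound 2 to compound 3 (0.08 log units; within the scatter), which is no step beyond the scatter and has no firm direction. For compound 3 the estimated value is 2500 nM, with an expected range of 1000 nM to 6000 nM.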

Compound 3, half-maximal effective concentration: 3700 nM
The estimate for compound 3 lay 1.5-fold (0.17 log units) below the measured number, within the range that was stated.
By their numbers in this assay, from the lowest: compounds 1, 2 and 3 (each within the scatter of the next, the first and the last beyond it).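

In this assay, among these compounds, the step from the 2-carboxyethenyl group to the carbamoyl group gives the first direct reading at this aromatic carbon, para to a large group: a 1.2-fold higher number from compound 2 to compound 3 (0.09 log units; within the scatter). This exchange of a group of 5 heavy atoms for one of 3 therefore shows no shift that can be told from the scatter. The replacement of 1,3-benzothiazol-2-yl by 4-carbamoylphenyl on the amide-type nitrogen gives a 2.5-fold higher number from compound 1 to compound 3 (0.39 log units; beyond the scatter), a modest step, but the first among these compounds to lie beyond the scatter, and nothing available explains the size of either step.

As far as these compounds go, it remains open whether a carboxylic acid set directly on that aromatic carbon, an amine, or a longer chain ending in an amide would also stay within the scatter of compound 2. From the compounds shown here alone, it is also open whether the step between compound 1 and compound 3 would persist with a phenyl group lacking the carbamoyl group on the amide-type nitrogen.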